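Swapping pyrimidin-2-yl for pyridin-2-yl on a second core

The source may report more compounds than this note shows. Statements on the series, on what has been measured and on what is new or still open speak of the compounds shown alone.

Four compounds share a fused two-ring core carrying an amide-type nitrogen, and they differ in the ring attached to that nitrogen and in how many chlorine atoms sit on the core. Compound 1 `O=C1c2cc(Cl)c(Cl)cc2C(=O)N1c1ncccn1` is the starting point; in a functional assay on the whole organism (serum, strain Swiss albino) with Rattus norvegicus as the target, read by spectrophotometry, with a stated time of 14 days, at a dose of 10 mg/kg by the oral route (a higher number here means more inhibition at the dose given (going by the name of the read-out), a lower number less inhibition), compound 1 gives 58%. Compound 2 `O=C1c2cc(Cl)c(Cl)cc2C(=O)N1c1ccccn1` keeps the same core but makes one change, (pyridin-2-yl in place of pyrimidin-2-yl on an amide-type nitrogen in a ring), and in this assay compound 2 gives 17%. That single change produced a number 41 percentage points lower from compound 1 to compound 2 (beyond the scatter).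

Compound 3 `O=C1c2c(Cl)c(Cl)c(Cl)c(Cl)c2C(=O)N1c1ncccn1` carries the pyrimidin-2-yl ring on a different core; how the two cores differ is not broken down here. In this assay compound 3 gives 3%, the lowest of the three measured numbers.

Compound 4 `O=C1c2c(Cl)c(Cl)c(Cl)c(Cl)c2C(=O)N1c1ccccn1`, not yet measured, makes the same change on compound 3 that compound 2 makes on compound 1: pyridin-2-yl in place of pyrimidin-2-yl on an amide-type nitrogen in a ring. The place is the same in both cases, so this is the same change seen a second time.

Compound 3 starts at 3%, so a drop like a number 41 percentage points lower from compound 1 to compound 2 (beyond the scatter) cannot be repeated in full. A percentage of inhibition cannot fall below nothing. The expected step of a number 1 percentage points lower from compound 3 to compound 4 (within the scatter) is therefore small, pressed against the floor. Compound 4 is expected to show 2% in this assay, with a likely range from 0% to 12%.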

Compound 4, a percentage reported as inhibition, in the whole organism at one dose (the size of the read-out at that dose, not a potency): 9%
For compound 4 the middle estimate is 7 percentage points below the measured one; the measured number falls inside the stated range.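

In this assay, replacing pyrimidin-2-yl with pyridin-2-yl on the amide-type nitrogen gives a number 6 percentage points higher from compound 3 to compound 4 (within the scatter), so on this core the swap cannot be told apart from the ordinary spread of repeated measurements. The effect of the swap therefore did not carry over unchanged from the core of compound 1 to the core of compound 3, and the two steps really do differ: the same change on two cores in this assay, a number 41 percentage points lower (beyond the scatter) from compound 1 to compound 2 and a number 6 percentage points higher (within the scatter) from compound 3 to compound 4, 47 percentage points apart, beyond the scatter of two such steps This does not show that the core of compound 3 makes the ring on the nitrogen unimportant, since compound 3 already reads 3%, which leaves almost no room for a further fall, and a read-out this close to nothing cannot reveal a loss of the size seen on the other core; nor do two cores give a rule for the whole series.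

The compounds shown leave open how a phenyl ring, or a pyridin-2-yl ring bearing an amine or a carboxylic acid, would behave on the same nitrogen. They also leave open whether the swap keeps its large effect on a core carrying a single chlorine atom or none, where the read-out might have more room to move.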